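Cytotoxicity notes on the piperazine and piperidine head groups

The source may hold more compounds than are shown below. What is called first, only, known or untested is meant among the compounds shown, and "the series" means these compounds.

Three compounds of the series carry a number or a limit in an ADME assay on HOS cells (Homo sapiens) for cytotoxicity; a lower number here means that less compound is tolerated, a higher number that more compound is tolerated. Compound 1 `CN(C)C1CCN(c2cccc3nc(CN(C)[C@H]4CCCc5cccnc54)cn23)CC1` gives 3400 nM in this assay, the lowest of the two numbers reported. Compound 2 `CCCCN(Cc1cn2c(N3CCN(C)CC3)cccc2n1)[C@H]1CCCc2cccnc21` gives 5300 nM in this assay, a gap to compound 1 that lies within the usual scatter, so the two are read as equal. For compound 3 `CN1CCN(c2cccc3nc(CN(C)[C@H]4CCCc5cccnc54)[nH]c23)CC1` this assay reports only a limit, > 5000 nM, and not a number (the limit of > 5000 nM in this assay, at which 1 of the 3 values shown sits).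

The unmeasured compound 4 `CCN1CCN(c2cccc3nc(CN(C)[C@H]4CCCc5cccnc54)cn23)CC1` differs from compound 1 in one place: 4-ethylpiperazin-1-yl in place of 4-(dimethylamino)piperidin-1-yl on an aromatic carbon. For the measured compounds named here, no pair of measured compounds covers this change, so there is no step to lean on; since compound 1 and compound 2 sit within scatter of each other and compound 3 only reaches a limit, the whole set spans little. Compound 4 is therefore expected to stay close to compound 1, with a 1.2-fold higher number from compound 1 to compound 4 (0.07 log units; within the scatter) estimated as no step beyond the scatter. The expected result for compound 4 in this assay is 4000 nM, within 1500 nM to 10000 nM.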

Compound 4, half-maximal cytotoxic concentration: 3900 nM
Beside the measured number, compound 4's estimate is 1.0-fold (0.01 log units) above it; measured number inside the range.
By their numbers in this assay, from the lowest: compounds 1, 4 and 2 (each within the scatter of the next).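

For the compounds shown here, at the place on an aromatic carbon next to the ring nitrogen, this assay gives the first comparison of the series in which only one place changes: 4-ethylpiperazin-1-yl in place of 4-(dimethylamino)piperidin-1-yl gives a 1.1-fold higher number from compound 1 to compound 4 (0.06 log units; within the scatter). The read-out therefore does not separate these two head groups on the shared core, although the change alters the ring from one hetero atom to two and moves the second nitrogen into the ring. No measurement shown here offers an explanation for this result.

Both groups are six-membered non-aromatic rings carrying two nitrogens and no hydrogen-bond donors, so this single step says little about a more different group at this place. A morpholine, a primary amine or a carboxylic acid there could behave otherwise, and the step may not hold on another core.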